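The source may hold more compounds than are shown below. What is called first, only, known or untested is meant among the compounds shown, and "the series" means these compounds.

Measured in a functional assay on EC9706 cells (Homo sapiens) for antiproliferative activity, read by MTT assay, with a stated time of 48 h; a lower number here means a stronger inhibitor, a higher number a weaker inhibitor:
- compound 1 `CCCCCCCn1cc(COC[C@@H]2OC[C@H](N)[C@@H]2O)nn1`: > 128000 nM, a limit of the assay and not a number
- compound 2 `CCCCCCCCCn1cc(COC[C@@H]2OC[C@H](N)[C@@H]2O)nn1`: 20100 nM
- compound 3 `CCCCCCCCCCn1cc(COC[C@@H]2OC[C@H](N)[C@@H]2O)nn1`: 15600 nM

Within the data shown here, compound 3 has one of only two true numbers here, and it lies within the scatter of compound 2. Compound 4 `CCCCCCCCCCCCCCn1cc(COC[C@@H]2OC[C@H](N)[C@@H]2O)nn1` differs from compound 3 by butyl in place of hydrogen on a saturated chain carbon, ten or more bonds along the chain from an aromatic nitrogen.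

Longer chains first brought clear gains, with an at least 6.3-fold lower number from compound 1 to compound 2 (0.80 log units; beyond the scatter) and an at least 8.2-fold lower number from compound 1 to compound 3 (0.91 log units; beyond the scatter), though both steps start from a limit. Compound 3 goes against this trend, with only a 1.3-fold lower number from compound 2 to compound 3 (0.11 log units; within the scatter). A small further drop is therefore expected in this assay, possibly within the scatter. The estimated step is a 1.7-fold lower number from compound 3 to compound 4 (0.24 log units; within the scatter). The expected value for compound 4 is 9000 nM, with an estimated range from 3000 nM to 30000 nM.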

Compound 4, half-maximal inhibitory concentration: 7830 nM
Compound 4: the middle estimate sits 1.1-fold (0.06 log units) above what was measured; the measured number falls inside the stated range.
By their numbers in this assay, from the lowest: compounds 4, 3 and 2 (each within the scatter of the next, the first and the last beyond it). At a limit, above all of these: compound 1.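

Butyl in place of hydrogen on a saturated chain carbon gives a single step that stays within the scatter: a 2.0-fold lower number from compound 3 to compound 4 (0.30 log units; within the scatter). Over a wider span, however, lengthening the chain still has a modest effect beyond the scatter: a 2.6-fold lower number from compound 2 to compound 4 (0.41 log units; beyond the scatter). The largest step, an at least 16-fold lower number from compound 1 to compound 4 (1.21 log units; beyond the scatter), starts from a limit, which belongs to compound 1: the limit of > 128000 nM in this assay, at which 1 of the 4 values shown sits.

On these data alone, whether a longer chain, or a chain carrying a carboxylic acid, would lower the number further remains open.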